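Carbamate in place of acetoxy on the fused ring

The source may report more compounds than this note shows. Statements on the series, on what has been measured and on what is new or still open speak of the compounds shown alone.

Measured compounds:
Compound 1, `O=C1C[C@@H]2CCCC[C@@H]2[C@H]1/C=C/c1ccc(-c2cccc(F)c2)cn1`: 1100 nM
Compound 2, `CC(=O)OC1C[C@@H]2CCCC[C@@H]2[C@H]1/C=C/c1ccc(-c2cccc(F)c2)cn1`: 67 nM
Compound 3, `NC1C[C@@H]2CCCC[C@@H]2[C@H]1/C=C/c1ccc(-c2cccc(F)c2)cn1`: 230 nM

Of the compounds shown here, three sharing one core have been measured in an assay on cell membranes for displacement of a labelled ligand from proteinase-activated receptor 1 (Homo sapiens), read by scintillation counting, with a stated time of 60 min; on this read-out lower numbers stand for stronger inhibition and higher numbers for weaker inhibition. Compound 1 gives 1100 nM, compound 3 gives 230 nM, and compound 2 gives 67 nM, the lowest of the three numbers. For the measured compounds named here, its nearest neighbour is compound 3, and the only single-point step among the measured compounds runs between these two: a 3.4-fold higher number from compound 2 to compound 3 (0.54 log units; beyond the scatter). Compound 1, with a ketone at the same position, stands furthest from compound 2.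

Compound 4, `COC(=O)NC1C[C@@H]2CCCC[C@@H]2[C@H]1/C=C/c1ccc(-c2cccc(F)c2)cn1`, has not yet been measured. It differs from compound 2 in one place: (methoxycarbonyl)amino in place of acetoxy on a saturated ring carbon. The step from compound 2 to compound 3 bears most directly on this change, since both replace the acetoxy group with a nitrogen-bearing group at the same carbon; that step was modest and went toward a higher number. The (methoxycarbonyl)amino group, however, keeps a carbonyl and two acceptors as the acetoxy group does, so a smaller shift than that seen for compound 3 is expected. The value of compound 4 in this assay is estimated at 90 nM, within a range of 30 nM to 300 nM, which corresponds to an expected 1.3-fold higher number from compound 2 to compound 4 (0.13 log units; within the scatter).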

Compound 4, half-maximal inhibitory concentration: 980 nM
Estimate against measurement, compound 4: 11-fold (1.04 log units) below; measured number above the stated range.
By their numbers in this assay, from the lowest: compound 2; then compound 3; then compounds 4 and 1 (each within the scatter of the next).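

In this assay, the acetoxy group and the (methoxycarbonyl)amino group have the same count of hydrogen-bond acceptors and each has a double bond outside aromatic rings, yet this change on the saturated ring carbon gave a 15-fold higher number from compound 2 to compound 4 (1.17 log units; beyond the scatter) and so went further than the earlier change to the plain amine, which gave a 3.4-fold higher number from compound 2 to compound 3 (0.54 log units; beyond the scatter). Putting methoxycarbonyl in place of hydrogen on the amine nitrogen also moved the number the same way, with a 4.3-fold higher number from compound 3 to compound 4 (0.63 log units; beyond the scatter), so at this position, among these three compounds, the plain amine stands between the acetoxy group and its carbamate. Nothing given here accounts for why the carbamate stands so far from the ester it replaced.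

The compounds shown leave open whether the result follows the amide hydrogen the carbamate brings in, the nitrogen itself or the extra methoxy part of the group. An acetamido group, which keeps the nitrogen without the methoxy oxygen, and a carbamate with a methyl group on its nitrogen, which has no amide hydrogen, would each bear on that question.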